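Swapping the pyrazine of compound 3 for an acyclic methoxyimine

A few compounds are considered here, and "the series" means these few. Any claim that something is new, unique, unknown or untested is made for them only; others in the source may bear on it.

This series varies the aryl group attached to the shared core of compound 1 `c1coc(-c2ccccc2NCC2=NCCN2)c1` and is followed in a functional assay for activation of Alpha-1B adrenergic receptor (Homo sapiens), read by calcium flux; a higher number here means that more compound is needed for the effect, a lower number that less compound is needed. In this assay compound 1 gives 6.31 nM, and compound 3 `c1ccc(-c2cnccn2)c(NCC2=NCCN2)c1` gives 339 nM. Compound 2 `Cc1nc(-c2ccccc2NCC2=NCCN2)co1` is reported only as a limit of this assay, < 5020 nM. Compound 3 therefore stands at the highest of the two read numbers, separated from compound 1 by a 54-fold higher number from compound 1 to compound 3 (1.73 log units; beyond the scatter). The steps that touch compound 2 are not readable as numbers because of the limit of < 5020 nM in this assay, at which 1 of the 3 values shown sits, so they are recorded as a step that the limit leaves unreadable from compound 1 to compound 2 and a step that the limit leaves unreadable from compound 2 to compound 3.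

Compound 4 `CO/N=C/c1ccccc1NCC1=NCCN1` changes compound 3 by a group of 4 heavy atoms (2 carbon, 1 nitrogen, 1 oxygen; no ring) in place of a group of 6 heavy atoms (4 carbon, 2 nitrogen; one six-membered aromatic ring with 2 hetero atoms), on an aromatic carbon. Among the measured compounds shown here, no measured step replaces an aromatic ring by an open chain, so the only guide is that the aryl group at this position has shifted the read-out by a large margin once already, as seen in the step from compound 1 to compound 3. A large step in either direction is therefore possible, and the estimate is kept wide. Compound 4 is expected to give about 150 nM, within 15 nM to 1500 nM, which means an expected step of a 2.3-fold lower number from compound 3 to compound 4 (0.35 log units; beyond the scatter).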

Compound 4, half-maximal effective concentration: < 5020 nM
Compound 4: no number, only a limit (the forecaster's own chance of this, stated with the estimate: 10%); the middle value does not contradict the limit.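

In this assay compound 4 is reported only as a limit, < 5020 nM, so none of its steps from compound 1, compound 2 or compound 3 can be read as a number: the limit of < 5020 nM in this assay, at which 2 of the 4 values shown sit.

The compounds shown leave open how far compound 2 and compound 4 actually lie from compound 3 in this assay, and whether these two differ from each other at all.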